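This account rests on a few compounds, and the source may have more. Where it says the series, first, only, none or still open, it means among the compounds named here.

Compound 1 `C[C@@H](CO)NC(=O)c1c(O)c2ncc(Cc3ccc(F)cc3)cc2n(C)c1=O` gives 1120 ng.h/mL 
Compound 2 `CNC(=O)c1c(O)c2ncc(Cc3ccc(F)cc3)cc2n(C)c1=O` gives 13200 ng.h/mL 

Of the two compounds measured in an ADME assay on the whole organism (plasma) for pharmacokinetics, with Canis familiaris (Canis lupus familiaris) as the target, at a dose of 5 mg/kg by the oral route (a higher number here means more compound in the circulation at the dose given, a lower number less compound in the circulation), compound 2 has the higher number, well clear of compound 1. Compound 3 `COCCNC(=O)c1c(O)c2ncc(Cc3ccc(F)cc3)cc2n(C)c1=O` differs from compound 2 by methoxymethyl in place of hydrogen on a saturated chain carbon bound to an amide-type nitrogen so that methyl becomes 2-methoxyethyl. Among the measured compounds shown here, only one measured step bears on this change: a 12-fold higher number from compound 1 to compound 2 (1.07 log units; beyond the scatter) with methyl in place of 1-(hydroxymethyl)ethyl on the same amide-type nitrogen. Read backwards, that large step suggests a fall when methyl gives way to a bigger oxygen-bearing chain. For the measured compounds named here, the entering group is not the one in compound 1, however, and a single step is thin evidence, so a fall somewhat smaller than that step is expected, with wide uncertainty. The step expected is a 3.8-fold lower number from compound 2 to compound 3 (0.58 log units; beyond the scatter) as estimated here. For compound 3 an estimate of 3500 ng.h/mL is expected, with 1000 ng.h/mL to 11000 ng.h/mL as its range.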

Compound 3, area under the concentration-time curve: 1240 ng.h/mL
Compound 3: the middle estimate sits 2.8-fold (0.45 log units) above what was measured, and the stated range covers the measured number.
By their numbers in this assay, from the lowest: compounds 1 and 3 (each within the scatter of the next); then compound 2.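

Going from methyl to 2-methoxyethyl on the amide-type nitrogen brings an 11-fold lower number from compound 2 to compound 3 (1.03 log units; beyond the scatter), so the large fall seen earlier is not confined to the branched 1-(hydroxymethyl)ethyl chain with its free hydroxyl. Between the two larger chains the data show a 1.1-fold higher number from compound 1 to compound 3 (0.04 log units; within the scatter), so in this assay 2-methoxyethyl and 1-(hydroxymethyl)ethyl cannot be told apart, and among these three compounds methyl alone stands clear. Nothing available explains why the number falls with either chain.

From the compounds shown here alone, whether a plain ethyl or a longer all-carbon chain on this nitrogen would already bring the fall, or whether oxygen in the chain is needed, stays open. How a chain ending in an amine or a carboxylic acid would read in this assay is also unknown.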